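The source may report more compounds than this note shows. Statements on the series, on what has been measured and on what is new or still open speak of the compounds shown alone.

Going by the values given here, compound 3 `Cc1ccc(C(=O)Nc2cccc(C(F)(F)F)c2)cc1-c1ccc2c(-c3cnn(CC(C)O)c3)n[nH]c2c1` holds the second place among the three numbers so far in an assay on isolated protein for inhibition of Discoidin domain-containing receptor 2 (Homo sapiens), read by ELISA, with a stated time of 60 min (a higher number here means a weaker inhibitor, a lower number a stronger inhibitor), where compound 3 gives 3.7 nM. Its nearest neighbour is compound 2 `CCCn1cc(-c2n[nH]c3cc(-c4cc(C(=O)Nc5cccc(C(F)(F)F)c5)ccc4C)ccc23)cn1`, which in this assay gives 3.2 nM; the furthest is compound 1 `Cc1ccc(C(=O)Nc2cccc(C(F)(F)F)c2)cc1-c1ccc2c(-c3cn[nH]c3)n[nH]c2c1`, which in this assay gives 55.6 nM. Compound 4 `Cc1ccc(C(=O)Nc2cccc(C(F)(F)F)c2)cc1-c1ccc2c(-c3cnn(C4CCOC4)c3)n[nH]c2c1` differs from compound 3 by oxolan-3-yl in place of 2-hydroxypropyl on an aromatic nitrogen. Among the compounds with values here, two measured steps bear on this: a 17-fold lower number from compound 1 to compound 2 (1.24 log units; beyond the scatter) and a 15-fold lower number from compound 1 to compound 3 (1.18 log units; beyond the scatter), both from placing a group on that nitrogen, whereas a 1.2-fold higher number from compound 2 to compound 3 (0.06 log units; within the scatter). Since a 1.2-fold higher number from compound 2 to compound 3 (0.06 log units; within the scatter), the hydroxy itself seems to matter little, so compound 4 is expected to move hardly at all, with a 1.1-fold lower number from compound 3 to compound 4 (0.02 log units; within the scatter). Compound 4 is estimated at 3.5 nM, between 1.5 nM and 9 nM.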

Compound 4, half-maximal inhibitory concentration: 6.2 nM
For compound 4 the middle estimate is 1.8-fold (0.25 log units) below the measured one; the range from low to high includes it.
By their numbers in this assay, from the lowest: compounds 2, 3 and 4 (each within the scatter of the next); then compound 1.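

In this assay, a ring on this nitrogen fares as well as an open chain: replacing 2-hydroxypropyl with oxolan-3-yl, which has no hydrogen-bond donor, gives a 1.7-fold higher number from compound 3 to compound 4 (0.22 log units; within the scatter), and replacing propyl gives a 1.9-fold higher number from compound 2 to compound 4 (0.29 log units; within the scatter). The gain over the bare nitrogen also holds for the ring, with a 9.0-fold lower number from compound 1 to compound 4 (0.95 log units; beyond the scatter). No measurement here explains why these groups behave alike. Still open, as far as these compounds go, is whether an amine or a carboxylic acid on this nitrogen, or a longer chain, would give similar numbers.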